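Chloro for Fluoro at the Limit of the Assay

A few compounds are considered here, and "the series" means these few. Any claim that something is new, unique, unknown or untested is made for them only; others in the source may bear on it.

Compound 1 `Cc1cccc(-n2cc(-c3ccccc3NS(=O)(=O)c3c[nH]c(=O)[nH]c3=O)nn2)c1`, compound 2 `Cc1ccc(-n2cc(-c3ccc(NS(=O)(=O)c4c[nH]c(=O)[nH]c4=O)cc3)nn2)cc1` and compound 3 `O=c1[nH]cc(S(=O)(=O)Nc2ccc(-c3cn(-c4ccccc4F)nn3)cc2)c(=O)[nH]1` share one core and differ in the group carried on the aromatic nitrogen. In a functional assay on HepG2 cells (Homo sapiens) for antiproliferative activity, read by MTT assay, with a stated time of 24 h (on this read-out higher numbers stand for weaker inhibition and lower numbers for stronger inhibition), compound 1 gives 3620 nM and compound 2 gives 11600 nM. For compound 3 this assay reports only a limit, > 20000 nM, and not a number. Compound 3 thus sits at the limit of > 20000 nM in this assay, at which 1 of the 3 values shown sits. Going by the values given here, the single step that can be sized, an at least 1.7-fold higher number from compound 2 to compound 3 (0.23 log units; that floor lies within the scatter), puts 2-fluorophenyl in place of 4-methylphenyl on an aromatic nitrogen, and its floor lies within the scatter.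

Compound 4 `O=c1[nH]cc(S(=O)(=O)Nc2ccc(-c3cn(-c4ccccc4Cl)nn3)cc2)c(=O)[nH]1` follows with a smaller change: chloro in place of fluoro on an aromatic carbon, the exchange sitting on an aromatic carbon of a six-membered aromatic ring of carbon only. Among the compounds with values here, no measured pair swaps one halogen for another, so none of the measured steps bears directly on this change; the halogen swap stands on its own. The step that the limit leaves unreadable from compound 3 to compound 4 is expected to be small, without a clear direction beyond the scatter. Compound 4 is therefore expected to give about 25000 nM in this assay, within a range from 8000 nM to 80000 nM, with a real chance that only a limit is reported again.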

Compound 4, half-maximal inhibitory concentration: 2230 nM
For compound 4 the middle estimate is 11-fold (1.05 log units) above the measured one; measured number below the stated range.
By their numbers in this assay, from the lowest: compounds 4 and 1 (each within the scatter of the next); then compound 2. At a limit, above all of these: compound 3.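

Chloro in place of fluoro on this aromatic carbon, ortho to a large group, moves the read-out in this assay beyond the scatter (an at least 8.9-fold lower number from compound 3 to compound 4 (0.95 log units; beyond the scatter)). So the exchange of one halogen atom for another, with no change in the counted hydrogen-bond donors or acceptors, matters at this position. That size is only a floor, because compound 3 carries a limit and not a number: (the limit of > 20000 nM in this assay, at which 1 of the 4 values shown sits). The earlier step from 4-methylphenyl to 2-fluorophenyl had a floor inside the scatter and so showed no clear effect of the group on the aromatic nitrogen, whereas 2-chlorophenyl in place of 4-methylphenyl now gives a clear difference (a 5.2-fold lower number from compound 2 to compound 4 (0.72 log units; beyond the scatter)).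

With only fluoro and chloro shown at this place, the compounds leave open whether the lower number is particular to chloro or would also appear with bromo, methyl or methoxy on the same carbon. On these data alone, the true number of compound 3 also stays unknown, so the full size of the exchange from fluoro to chloro cannot be read.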